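A few compounds are considered here, and "the series" means these few. Any claim that something is new, unique, unknown or untested is made for them only; others in the source may bear on it.

Notes on the series. In a physicochemical assay for solubility, in phosphate buffer, at pH 6.5 (a lower number here means a less soluble compound, a higher number a more soluble compound), compound 2 `CCOc1cc(CN2CCC(NC(=O)c3cncc(C)c3)CC2)cc(OCC)c1-c1ccc(F)cc1` gives 94 ug/mL. In this assay compound 1 `CCOc1cc(CN2CCC(NC(=O)c3ccc(N)nc3)CC2)cc(OCC)c1-c1ccc(F)cc1` gives 123 ug/mL. Going by the values given here, compound 2 therefore holds the lower of the two numbers so far, with compound 1 the nearest neighbour, and the only measured step in the set is a 1.3-fold lower number from compound 1 to compound 2 (0.12 log units; within the scatter). Compound 3 `CCOc1cc(CN2CCC(NC(=O)c3ccc(NC)nc3)CC2)cc(OCC)c1-c1ccc(F)cc1` is not yet measured in this assay. Among the compounds with values here, it differs from compound 2 in one place: 6-(methylamino)pyridin-3-yl in place of 5-methylpyridin-3-yl on a carbonyl carbon The one measured step that bears on this change is a 1.3-fold lower number from compound 1 to compound 2 (0.12 log units; within the scatter), which connects the same 5-methylpyridin-3-yl to a 6-aminopyridin-3-yl on the carbonyl carbon; compound 3 instead carries 6-(methylamino)pyridin-3-yl, a close relative of the group in compound 1. Since that step stayed within the scatter, no step beyond the scatter is expected here either, in either direction. The expected step is a 1.1-fold higher number from compound 2 to compound 3 (0.05 log units; within the scatter). For compound 3 the estimated value in this assay is 105 ug/mL, with a range from 50 ug/mL to 210 ug/mL.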

Compound 3, solubility: 153 ug/mL
Compound 3: middle estimate off by 1.5-fold (0.16 log units), on the low side; the measured number falls inside the stated range.
By their numbers in this assay, from the lowest: compounds 2, 1 and 3 (each within the scatter of the next).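

Working notes. In this assay the step of a 1.6-fold higher number from compound 2 to compound 3 (0.21 log units; within the scatter) stays within the scatter, even though the entering 6-(methylamino)pyridin-3-yl has 1 hydrogen-bond donor and 2 hydrogen-bond acceptors, against 0 and 1 on the leaving 5-methylpyridin-3-yl. Going by these compounds alone, the new pair adds a test the earlier compounds could not give, methyl in place of hydrogen on a nitrogen on an aromatic ring, and the step of a 1.2-fold higher number from compound 1 to compound 3 (0.09 log units; within the scatter) also stays within the scatter. With these steps and the earlier one all within the scatter, the three groups on the carbonyl carbon cannot be put in any order in this assay, and this position has so far shown no step beyond the scatter.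

Still open, as far as these compounds go, is whether a dimethylamino group or a longer chain such as ethylamino in place of the methylamino group would give a step beyond the scatter. Also open, from the compounds shown here alone, is whether a carboxylic acid on the pyridine ring would separate from these three compounds in this assay and whether the same changes read alike on a different core. Nothing at hand accounts for how closely these values sit.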